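Chloro and methyl trade places on compound 2

The source may report more compounds than this note shows. Statements on the series, on what has been measured and on what is new or still open speak of the compounds shown alone.

Compound 1 `Cc1ccc(Nc2ncc(C(F)(F)F)c(N3Cc4cccc(N(C)S(C)(=O)=O)c4C3)n2)cc1C` with > 30000 nM as a limit of the assay
Compound 2 `Cc1ccc(Nc2ncc(C(F)(F)F)c(N3Cc4cccc(N(C)S(C)(=O)=O)c4C3)n2)c(Cl)c1` with 10900 nM as its value
Compound 3 `CN(c1cccc2c1CN(c1nc(Nc3cccc(Oc4ccccc4)c3)ncc1C(F)(F)F)C2)S(C)(=O)=O` with 4300 nM as its value

In a functional assay on HeLa cells (Homo sapiens) for antiproliferative activity, read by spectrophotometry, with a stated time of 2 days (on this read-out lower numbers stand for stronger inhibition of growth and higher numbers for weaker inhibition of growth), compound 2 (10900 nM) holds the higher of the two actual numbers, and compound 3 (4300 nM) holds the lower. Compound 1 (> 30000 nM) gives a limit and not a number.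

Compound 4 `Cc1cc(Cl)ccc1Nc1ncc(C(F)(F)F)c(N2Cc3cccc(N(C)S(C)(=O)=O)c3C2)n1` differs from compound 2 by one change 4-chloro-2-methylphenyl in place of 2-chloro-4-methylphenyl on a nitrogen on an aromatic ring and carries 4-chloro-2-methylphenyl in place of 2-chloro-4-methylphenyl on a nitrogen on an aromatic ring. Among the measured compounds shown here, one measured step bears on this place: an at least 2.7-fold lower number from compound 1 to compound 2 (0.43 log units; beyond the scatter) with 2-chloro-4-methylphenyl in place of 3,4-dimethylphenyl. For the measured compounds named here, that step shows that the group here can move the number beyond the scatter, but no measured step exchanges the two groups in question, and no direction can be read from the data. The expected step is a 1.1-fold higher number from compound 2 to compound 4 (0.04 log units; within the scatter) and it is expected to stay within the scatter. The estimated value of compound 4 is 12000 nM (expected range 4000 nM to 30000 nM).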

Compound 4, concentration for 50% growth inhibition: 17400 nM
Estimate against measurement, compound 4: 1.5-fold (0.16 log units) below; the range from low to high includes it.
By their numbers in this assay, from the lowest: compound 3; then compounds 2 and 4 (each within the scatter of the next). At a limit, above all of these: compound 1.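

On a nitrogen on an aromatic ring, the groups 2-chloro-4-methylphenyl and 4-chloro-2-methylphenyl hold the same atoms joined differently, and exchanging them gives a 1.6-fold higher number from compound 2 to compound 4 (0.20 log units; within the scatter) in this assay, so this exchange of chloro and methyl is not shown to matter here. Measured against 3,4-dimethylphenyl, 4-chloro-2-methylphenyl gives an at least 1.7-fold lower number from compound 1 to compound 4 (0.23 log units; that floor lies within the scatter), a weaker reading than the earlier step of an at least 2.7-fold lower number from compound 1 to compound 2 (0.43 log units; beyond the scatter), which cleared the scatter. Compound 1 gives only a limit, so this comparison has a floor and no size: the limit of > 30000 nM in this assay, at which 1 of the 4 values shown sits.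

The compounds shown leave open whether an amine or a carboxylic acid on this phenyl ring, in place of chloro or methyl, would move the number beyond the scatter from compound 2. They also leave open whether the two chloro-methylphenyl groups would stay this close on a different core.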